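The compounds below may be only part of what the source reports. "The series", "measured", "known", "first", "only" and "open" are said of these compounds alone.

Working notes on the series.

Of the compounds shown here, two have been tested in an ADME assay on HepG2 cells (Homo sapiens) for cytotoxicity, read by MTT assay, with a stated time of 72 h; a higher number here means that more compound is tolerated, a lower number that less compound is tolerated. Compound 1, `O=[N+]([O-])c1c(CSc2ccccc2)nc2c(Sc3ccc(Cl)cc3)cc(Cl)cn12`, gives in this assay a value reported only as a limit of the measurement, > 15600 nM. Compound 2, `COc1ccc(Nc2cc(Cl)cn3c([N+](=O)[O-])c(CS(=O)(=O)c4ccccc4)nc23)cc1`, gives in this assay likewise only a limit, > 3900 nM. Compound 2 therefore stands at one of the two limits that the series has so far produced in this assay: one value sits at the limit of > 15600 nM in this assay, at which 1 of the 2 values shown sits, and the other at the limit of > 3900 nM in this assay, at which 1 of the 2 values shown sits, and neither is a number; both compounds were tolerated up to the concentration tested.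

The next compound, compound 3, `O=[N+]([O-])c1c(CS(=O)(=O)c2ccccc2)nc2c(Nc3ccccc3)cc(Cl)cn12`, differs from compound 2 in one place: hydrogen in place of methoxy on an aromatic carbon.

For the measured compounds named here, no step between measured compounds is known, so the expected size of this step rests on the structural change alone. Going by the values given here, the step from compound 2 to compound 3 in this assay is expected to be no more than a step that the limit leaves unreadable from compound 2 to compound 3, within the scatter. For compound 3 in this assay the value is estimated at 8000 nM, in a range from 2500 nM to 30000 nM, most probably again reported only as a limit.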

Compound 3, half-maximal cytotoxic concentration: > 3900 nM
Compound 3: only a limit was reported; the forecaster's own chance of this, stated with the estimate: 70%; the middle value does not contradict the limit.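

In this assay, for the compounds shown here, compound 2 and compound 3 are both reported only as limits, so no step between the two can be read. The compounds shown leave open where the actual half-maximal cytotoxic concentration of any of them lies, and whether hydrogen in place of methoxy changes it at all.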